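This account rests on a few compounds, and the source may have more. Where it says the series, first, only, none or still open, it means among the compounds named here.

Compound 2 `CNC(=O)c1cc(Oc2ccc(C(=O)/C=C/c3cccc([N+](=O)[O-])c3)cc2)ccn1` shares its core with compound 1 `CNC(=O)c1cc(Oc2ccc(/C=C/C(=O)c3ccc([N+](=O)[O-])cc3)cc2)ccn1` and compound 3 `CNC(=O)c1cc(Oc2ccc(C(=O)/C=C/c3ccc(F)cc3Cl)cc2)ccn1`. In a functional assay on HepG2 cells (Homo sapiens) for cytotoxicity, read by MTT assay, with a stated time of 72 h (on this read-out higher numbers stand for weaker inhibition and lower numbers for stronger inhibition), compound 1 gives 41400 nM. For compound 2, this assay reports only a limit, > 50000 nM, so compound 2 stands at the weak end of the three values shown (the limit of > 50000 nM in this assay, at which 1 of the 3 values shown sits). Compound 3 gives 7320 nM. Going by the values given here, the only measured step, an at least 6.8-fold lower number from compound 2 to compound 3 (0.83 log units; beyond the scatter), swaps the whole ring at that position, so it bears only loosely on the change to compound 4 `CNC(=O)c1cc(Oc2ccc(C(=O)/C=C/c3ccccc3)cc2)ccn1`, which is hydrogen in place of nitro on an aromatic carbon. Since compound 2 sits at the limit, the step is expected to run toward stronger inhibition, an at least 1.6-fold lower number from compound 2 to compound 4 (0.22 log units; that floor lies within the scatter), yet to stay small. Compound 4 is therefore estimated at 30000 nM, within 9000 nM to 60000 nM.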

Compound 4, half-maximal inhibitory concentration: 6640 nM
Beside the measured number, compound 4's estimate is 4.5-fold (0.65 log units) above it, and the stated range ends above it.
By their numbers in this assay, from the lowest: compounds 4 and 3 (each within the scatter of the next); then compound 1. At a limit, above all of these: compound 2.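

Taking away the nitro group alone, with hydrogen in its place on the aromatic carbon, gives an at least 7.5-fold lower number from compound 2 to compound 4 (0.87 log units; beyond the scatter) in this assay and so shows that this single change is enough for a clear step. The bare phenyl ring also holds its own against the halogenated ring, with a 1.1-fold lower number from compound 3 to compound 4 (0.04 log units; within the scatter) and so no gain from the chlorine and fluorine together. The first step is only a floor, because compound 2 stands at a limit: the limit of > 50000 nM in this assay, at which 1 of the 4 values shown sits.

From the compounds shown here alone, what an amine or a carboxylic acid at this place on the ring would do stays open. So does whether removing nitro would give a similar step on compound 1.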